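The source may hold more compounds than are shown below. What is called first, only, known or untested is meant among the compounds shown, and "the series" means these compounds.

In a functional assay on SMMC-7721 cells (Homo sapiens) for cytotoxicity, read by MTT assay, with a stated time of 48 h (a higher number here means a weaker inhibitor, a lower number a stronger inhibitor), compound 1 (`O=c1cc(-c2ccc([N+](=O)[O-])cc2)oc2ccc(CN3CCCCC3)cc12`) is entered as "not determined" (no result reported). Compound 2 (`CCN(CC)Cc1cccc2c(=O)cc(-c3ccc([N+](=O)[O-])cc3)oc12`) is entered as "not determined" (no result reported). Compound 3 (`CCN(CC)Cc1cc(Cl)cc2c(=O)cc(-c3ccc([N+](=O)[O-])cc3)oc12`) gives 2990 nM and so stands alone, with nothing to rank it against. Compound 4 (`CN(C)Cc1cc(Cl)cc2c(=O)cc(-c3ccc([N+](=O)[O-])cc3)oc12`) differs from compound 3 in one place, with dimethylamino in place of diethylamino on a saturated chain carbon bound to an aromatic carbon. Among the compounds with values here, no step between measured compounds shows what such a change does in this assay and no shift beyond the scatter is expected. The estimated step is a 1.1-fold higher number from compound 3 to compound 4 (0.03 log units; within the scatter) and it is expected to stay small. Compound 4 is expected at 3200 nM in this estimate, with 1200 nM to 8500 nM as the likely range.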

Compound 4, half-maximal inhibitory concentration: 56500 nM
Compound 4: the middle estimate sits 18-fold (1.25 log units) below what was measured; the measured number lies above the stated range.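

In this assay, putting dimethylamino in place of diethylamino on a saturated chain carbon bound to an aromatic carbon gives a 19-fold higher number from compound 3 to compound 4 (1.28 log units; beyond the scatter) and so shows that the number responds strongly to this exchange, which compound 3 alone could not show. The direction is clear: the group with fewer carbons gives the weaker inhibitor in this pair. Nothing available accounts for the size of this step. The compounds shown leave open whether dipropylamino, with its longer chains, or a morpholine ring at this place would lower the number or raise it further.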